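The source may hold more compounds than are shown below. What is called first, only, known or untested is meant among the compounds shown, and "the series" means these compounds.

Measured so far:
compound 1 `COc1c(/C=C2/C(=O)Nc3ccccc32)c2ccccc2n1-c1ccccc1` — 1050 nM
compound 2 `COc1c(/C=C2/C(=O)Nc3ccc(Cl)cc32)c2ccccc2n1-c1ccccc1` — 6310 nM

In a functional assay on cells (Cancer cell lines, Homo sapiens) for cytotoxicity, with a stated time of 48 h (on this read-out lower numbers stand for stronger inhibition of growth and higher numbers for weaker inhibition of growth), compound 1 gives 1050 nM, while compound 2 gives 6310 nM, the higher of the two numbers. Among the measured compounds shown here, the only step recorded between them is a 6.0-fold higher number from compound 1 to compound 2 (0.78 log units; beyond the scatter), so adding chloro at that position weakened growth inhibition by a modest margin. Compound 3 `COc1ccc2c(c1)/C(=C\c1c(OC)n(-c3ccccc3)c3ccccc13)C(=O)N2` carries a different group at the same place: methoxy in place of chloro on an aromatic carbon. For the measured compounds named here, no measured step shows what a methoxy does there, so the chloro-for-hydrogen step is the only guide, and it bears only loosely on this change. Because the chloro cost seen in a 6.0-fold higher number from compound 1 to compound 2 (0.78 log units; beyond the scatter) might be partly undone by a different substituent, a moderate change toward lower numbers is expected, though a result near compound 2 would not surprise. The expected step is a 2.1-fold lower number from compound 2 to compound 3 (0.32 log units; beyond the scatter). Compound 3 is therefore estimated at 3000 nM, with a range from 800 nM to 12000 nM.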

Compound 3, concentration for 50% growth inhibition: 1740 nM
Beside the measured number, compound 3's estimate is 1.7-fold (0.24 log units) above it; measured number inside the range.
By their numbers in this assay, from the lowest: compounds 1 and 3 (each within the scatter of the next); then compound 2.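

In this assay, this aromatic carbon does not respond the same way to every group placed on it: methoxy in place of chloro gives (a 3.6-fold lower number from compound 2 to compound 3 (0.56 log units; beyond the scatter)), so the outcome depends on which group sits there, not only on whether the hydrogen has been replaced. Methoxy in place of hydrogen gives (a 1.7-fold higher number from compound 1 to compound 3 (0.22 log units; within the scatter)), so compound 1 and compound 3 cannot be told apart on this read-out, whereas compound 2 stands apart from both. No supporting measurement accounts for the difference between the chloro and methoxy groups.

The compounds shown leave open how an amine, a hydroxyl or a longer chain such as ethoxy would behave on this carbon. They also leave open whether any group there could give clearly stronger growth inhibition than the hydrogen of compound 1.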